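The compounds below may be only part of what the source reports. "The series", "measured", "known", "first", "only" and "open" are said of these compounds alone.

Of the compounds shown here, three sharing one core have been tested in an ADME assay on A549 cells (Homo sapiens) for cytotoxicity, with a stated time of 72 h; a higher number here means a weaker inhibitor, a lower number a stronger inhibitor. Compound 1, `COc1cc(NC(C)CCCN2C(=O)CN(C(=O)CN)C2(C)C)c2ncccc2c1`, reaches only a limit of the assay in this assay, > 100000 nM, which is the limit of > 100000 nM in this assay, at which 1 of the 3 values shown sits. Compound 2, `COc1cc(NC(C)CCCN2C(=O)CN(C(=O)[C@H](N)C(C)C)C2(C)C)c2ncccc2c1`, gives 5500 nM in this assay. Compound 3, `COc1cc(NC(C)CCCN2C(=O)CN(C(=O)[C@@H](C)N)C2(C)C)c2ncccc2c1`, gives 7800 nM in this assay. Of the two real numbers shown, the values of compound 3 and compound 2 lie within the scatter of each other, so neither can be called weaker or stronger.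

Compound 4, `COc1cc(NC(C)CCCN2C(=O)CN(C(=O)[C@H](N)CC(C)C)C2(C)C)c2ncccc2c1`, differs from compound 3 in one place: isopropyl in place of hydrogen on a saturated chain carbon, two bonds along the chain from an amine nitrogen and a carbonyl carbon.

Two kinds of measured step bear on this change. The steps of an at least 12-fold lower number from compound 1 to compound 3 (1.10 log units; beyond the scatter) and an at least 18-fold lower number from compound 1 to compound 2 (1.25 log units; beyond the scatter) show that an alkyl group on the chain carbon bound to the amine nitrogen and the carbonyl carbon lowered the number strongly. The step of a 1.4-fold higher number from compound 2 to compound 3 (0.15 log units; within the scatter), however, shows that enlarging methyl to isopropyl on that same carbon changed little. The isopropyl of compound 4 enters two bonds along the chain from the amine nitrogen and the carbonyl carbon, further out than either of those changes. A step within the scatter, perhaps slightly lower, is therefore expected, namely a 1.6-fold lower number from compound 3 to compound 4 (0.19 log units; within the scatter). Compound 4 is estimated at 5000 nM, in a range from 2000 nM to 15000 nM.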

Compound 4, half-maximal inhibitory concentration in the A549 assay: 21200 nM
The estimate for compound 4 lay 4.2-fold (0.63 log units) below the measured number; measured number above the stated range.
By their numbers in the A549 assay, from the lowest: compounds 2 and 3 (each within the scatter of the next); then compound 4. At a limit, above all of these: compound 1.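

In the A549 assay, isobutyl on this carbon gives a 2.7-fold higher number from compound 3 to compound 4 (0.43 log units; beyond the scatter) and a 3.9-fold higher number from compound 2 to compound 4 (0.59 log units; beyond the scatter), so enlarging the alkyl group this far raises the number again, while an at least 4.7-fold lower number from compound 1 to compound 4 (0.67 log units; beyond the scatter) remains, a step read from a limit of the assay. The same kind of change moved the number in opposite directions, depending on where it was made: the same change on two cores in the A549 assay, an at least 18-fold lower number (1.25 log units; beyond the scatter) from compound 1 to compound 2 and a 2.7-fold higher number (0.43 log units; beyond the scatter) from compound 3 to compound 4, at least 49-fold (1.69 log units) apart, beyond the scatter of two such steps In a physicochemical assay for solubility (a lower number here means a less soluble compound, a higher number a more soluble compound), compound 3 gives 120000 ug/mL and compound 4 gives 26600 ug/mL, which is a 4.5-fold lower number from compound 3 to compound 4 (0.65 log units; beyond the scatter).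

Three alkyl groups cannot show whether the number in the A549 assay keeps rising with size or depends on the branching of the chain. As far as these compounds go, how a longer unbranched chain, a phenyl group or a carboxylic acid on this carbon would behave in either assay remains open.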